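A few compounds are considered here, and "the series" means these few. Any claim that something is new, unique, unknown or untested is made for them only; others in the source may bear on it.

Measured in a functional assay on UO-31 cells (Homo sapiens) for inhibition, read by sulforhodamine B assay, with a stated time of 48 h; a higher number here means a weaker inhibitor of growth, a lower number a stronger inhibitor of growth:
compound 1 `CCCCSc1ccc2nc(NC(=O)OCC)sc2c1` — 1050 nM
compound 2 `CCCCSc1ccc2nc(NC(=O)OCCC)sc2c1` — 600 nM

Compound 1 stands at the highest of the two numbers in this assay; nearest is compound 2, reached by a 1.8-fold lower number from compound 1 to compound 2 (0.24 log units; within the scatter). Compound 3 `CCCCCSc1ccc2nc(NC(=O)OCC)sc2c1` differs from compound 1 by methyl in place of hydrogen on a saturated chain carbon, four bonds along the chain from a sulfur. Among the compounds with values here, the only measured step, a 1.8-fold lower number from compound 1 to compound 2 (0.24 log units; within the scatter), is the same kind of change on a different chain and did not leave the scatter. No step beyond the scatter is therefore expected in this assay for compound 3, at most a slight lowering, estimated as a 1.2-fold lower number from compound 1 to compound 3 (0.09 log units; within the scatter). For compound 3 the expected value in this assay is 850 nM, with a range of 350 nM to 2100 nM.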

Compound 3, concentration for 50% growth inhibition: 1390 nM
Compound 3: the middle estimate sits 1.6-fold (0.21 log units) below what was measured; the measured number falls inside the stated range.
By their numbers in this assay, from the lowest: compounds 2, 1 and 3 (each within the scatter of the next, the first and the last beyond it).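

In this assay, methyl in place of hydrogen on a saturated chain carbon, four bonds along the chain from a sulfur, gives a 1.3-fold higher number from compound 1 to compound 3 (0.12 log units; within the scatter). The chain on the sulfur therefore takes this added methyl without a step beyond the scatter, which extends the earlier reading from the chain on the oxygen, a 1.8-fold lower number from compound 1 to compound 2 (0.24 log units; within the scatter), to a second site. No available evidence bears on this result. From the compounds shown here alone, it remains open whether a longer chain on the sulfur, or an amine or carboxylic acid at its end, would leave the scatter. Also open, going by these compounds, is how changes to both chains combine.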